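The compounds below may be only part of what the source reports. "The series", "measured", "known", "first", "only" and "open" are said of these compounds alone.

Measured compounds:
Compound 1 `Cc1c(O)ccc2c1[C@H](Cn1cc(-c3ccccc3)nn1)[C@@]13CC(=O)[C@@](C)(CC[C@@H]21)C3` in a functional assay on HL-60 cells (Homo sapiens) for cytotoxicity, read by MTT assay, with a stated time of 4 days (on this read-out lower numbers stand for stronger inhibition and higher numbers for weaker inhibition), gives > 20000 nM, which is a limit of the assay.
Compound 2 `Cc1ccc(S(=O)(=O)Oc2ccc3c(c2C)[C@H](Cn2cc(-c4ccccc4)nn2)[C@@]24CC(=O)[C@@](C)(CC[C@@H]32)C4)cc1` in this assay gives > 20000 nM, again a limit of the assay.
Compound 3 `C=C1C[C@]23C[C@@]1(O)CC[C@H]2c1cc(Br)c(O)c(C)c1[C@@H]3Cn1cc(-c2ccc(F)cc2)nn1` in this assay gives 6600 nM.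

Compound 2 therefore stands at the limit, not at a number; two of the three values sit there (the limit of > 20000 nM in this assay, at which 2 of the 3 values shown sit). Among the compounds with values here, the only step that joins two measured compounds, a step that the two limits leave unreadable from compound 1 to compound 2, is unreadable for the same reason. Within the data shown here, compound 3 is the one value with a number, but no step joins it to compound 2.

Compound 4 `Cc1ccc(-c2cn(C[C@H]3c4c(ccc(OS(=O)(=O)c5ccc(C)cc5)c4C)[C@@H]4CC[C@@]5(C)C[C@]43CC5=O)nn2)cc1` differs from compound 2 by methyl in place of hydrogen on an aromatic carbon, para to a large group. No measured step touches this position, so nothing shown bears directly on it. Given that compound 2 sits at the limit, and that the one readable step in the series is itself unreadable, the expectation is no step beyond the scatter in this assay, with the assay most likely again reporting only a limit.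

Compound 4 is therefore estimated at 25000 nM (range 8000 nM to 80000 nM). The step from compound 2 to compound 4 that this estimate means, a step that the limit leaves unreadable from compound 2 to compound 4, is expected to lie within the scatter.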

Compound 4, half-maximal inhibitory concentration: > 20000 nM
Compound 4: no number, only a limit; the forecaster's own chance of this, stated with the estimate: 70%; the middle value lies beyond the limit too.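

In this assay compound 4 gives > 20000 nM, a limit of the assay. Compound 2 and compound 4 both stand at a limit, so no step can be read between them: the limit of > 20000 nM in this assay, at which 3 of the 4 values shown sit.

The compounds shown leave open whether phenyl to 4-methylphenyl changes the read-out at all.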